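The source may report more compounds than this note shows. Statements on the series, on what has been measured and on what is new or still open speak of the compounds shown alone.

Measured so far:
Compound 1, `NC(=O)c1c(NC(=O)c2ccccc2Br)sc2c1CCN(C(=S)Nc1ccccc1Cl)C2`: 12900 nM
Compound 2, `NC(=O)c1c(NC(=O)c2ccccc2Br)sc2c1CCN(C(=S)Nc1ccccc1F)C2`: > 50000 nM
Compound 3, `NC(=O)c1c(NC(=O)c2ccccc2Br)sc2c1CCN(C(=S)Nc1ccccc1Br)C2`: 13700 nM

In a functional assay on MKN-74 cells (Homo sapiens) for antiproliferative activity, with a stated time of 24 h (a lower number here means a stronger inhibitor, a higher number a weaker inhibitor), compound 3 gives 13700 nM, the higher of the two numbers, with compound 1 nearest at a 1.1-fold higher number from compound 1 to compound 3 (0.03 log units; within the scatter). The value of compound 2 is a limit of the assay, not a number (the limit of > 50000 nM in this assay, at which 1 of the 3 values shown sits). Compound 4 is `Cc1ccccc1NC(=S)N1CCc2c(sc(NC(=O)c3ccccc3Br)c2C(N)=O)C1`, differing from compound 3 by methyl in place of bromo on an aromatic carbon. Among the measured compounds shown here, no measured step swaps bromo for methyl; the halogen swaps show a 1.1-fold higher number from compound 1 to compound 3 (0.03 log units; within the scatter) but an at least 3.6-fold lower number from compound 2 to compound 3 (0.56 log units; beyond the scatter). With only these steps, a change within the scatter is expected, so compound 4 is estimated at 15000 nM (range 6000 nM to 45000 nM), a step of a 1.1-fold higher number from compound 3 to compound 4 (0.04 log units; within the scatter).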

Compound 4, half-maximal inhibitory concentration: > 50000 nM
Compound 4: only a limit was reported; the forecaster's own chance of this, stated with the estimate: 20%; middle value at least 3.3-fold (0.52 log units) away from the limit.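

In this assay, compound 4 gives only a limit of the assay, not a number, and so does compound 2: the limit of > 50000 nM in this assay, at which 2 of the 4 values shown sit. Methyl in place of bromo gives an at least 3.6-fold higher number from compound 3 to compound 4 (0.56 log units; beyond the scatter), and methyl in place of chloro gives an at least 3.8-fold higher number from compound 1 to compound 4 (0.58 log units; beyond the scatter), so swapping one heavy atom for another on this aromatic carbon is enough to lose a measurable number. The step from compound 2 to compound 4 cannot be read.

The compounds shown leave open why only chloro and bromo give numbers here. They also leave open how a methoxy group or an amine at this position would read.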